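A few compounds are considered here, and "the series" means these few. Any claim that something is new, unique, unknown or untested is made for them only; others in the source may bear on it.

Compound 1 `CN(C)CCN1CCN(CC(=O)Nc2ccc(-c3nc4cc(Cl)ccc4o3)cc2)CC1` gives 2640 nM in a functional assay on HepG2 cells (Homo sapiens) for cytotoxicity, read by MTT assay, with a stated time of 24 h; a lower number here means a stronger inhibitor, a higher number a weaker inhibitor. Compound 2 `CN(C)CCN1CCN(CC(=O)Nc2ccc(-c3nc4ccccc4o3)cc2)CC1` gives 16300 nM in this assay. Going by the values given here, the single change between them, (hydrogen in place of chloro on an aromatic carbon), made a step of a 6.2-fold higher number from compound 1 to compound 2 (0.79 log units; beyond the scatter). Compound 3 `Cc1cc(-c2nc3cc(Cl)ccc3o2)ccc1NC(=O)CN1CCN(CCCN(C)C)CC1` gives 11200 nM in this assay; the difference between its core and the core of compound 1 is not broken down here. Compound 4 `Cc1cc(-c2nc3ccccc3o2)ccc1NC(=O)CN1CCN(CCCN(C)C)CC1` stands to compound 3 as compound 2 stands to compound 1, through (hydrogen in place of chloro on an aromatic carbon), the second appearance of this change among these compounds. Because that change once made the step of a 6.2-fold higher number from compound 1 to compound 2 (0.79 log units; beyond the scatter), the expected step here is a 4.0-fold higher number from compound 3 to compound 4 (0.60 log units; beyond the scatter). Compound 4 is accordingly estimated at 45000 nM, with a wide range because a single earlier instance is all that supports the expectation.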

Compound 4, half-maximal inhibitory concentration: 2160 nM
Beside the measured number, compound 4's estimate is 21-fold (1.32 log units) above it; the measured number lies below the stated range.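

In this assay, putting hydrogen in place of chloro gave a 5.2-fold lower number from compound 3 to compound 4 (0.71 log units; beyond the scatter), so the step did not carry over from the earlier pair, and its direction was opposite. Set side by side, the two instances of this change disagree: the same change on two cores in this assay, a 6.2-fold higher number (0.79 log units; beyond the scatter) from compound 1 to compound 2 and a 5.2-fold lower number (0.71 log units; beyond the scatter) from compound 3 to compound 4, 32-fold (1.51 log units) apart, beyond the scatter of two such steps

Within these four compounds, the outcome of going from 5-chloro-1,3-benzoxazol-2-yl to 1,3-benzoxazol-2-yl therefore depends on the core that carries it, but this does not show which feature of the cores is responsible.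

Going by these compounds, it remains open whether the methyl group or the longer chain of compound 3, taken alone, goes with the opposite direction. On these data alone, it also remains open how fluoro or bromo in place of chloro would behave on either core.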